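Ethyl to Methoxy on the Shared Core

The compounds below may be only part of what the source reports. "The series", "measured", "known", "first", "only" and "open" are said of these compounds alone.

Compound 2 `CCc1ccc2nc(C(=O)Nc3c(F)cc(-c4cccc(F)c4)cc3F)c(C)c(C(=O)O)c2c1` stands highest of the two compounds measured in a functional assay on A-375 cells (Homo sapiens) for antiproliferative activity, read by MTT assay, with a stated time of 24 h, tested at 33.33 ug/mL (a higher number here means a stronger effect of the compound at the concentration tested, a lower number a weaker effect), where compound 2 gives 47.1%. Compound 1 `CCOc1ccc2nc(C(=O)Nc3c(F)cc(-c4cccc(F)c4)cc3F)c(C)c(O)c2c1` differs from compound 2 in several places. In this assay compound 1 gives 16.3%, a gap beyond the usual scatter. Compound 3 `COc1ccc2nc(C(=O)Nc3c(F)cc(-c4cccc(F)c4)cc3F)c(C)c(C(=O)O)c2c1` has not yet been measured; its change from compound 2 is methoxy in place of ethyl on an aromatic carbon. Within the data shown here, no single-change step is recorded, so only a modest shift is expected, most likely a small drop. Compound 3 is therefore estimated at 38%, within 20% to 55%. The expected step of a number 9.1 percentage points lower from compound 2 to compound 3 (within the scatter) stays near the scatter.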

Compound 3, a percentage reported as inhibition, at one concentration (the size of the read-out at that concentration, not a potency): 44.5%
Estimate against measurement, compound 3: 6.5 percentage points below; the range from low to high includes it.
By their numbers in this assay, from the lowest: compound 1; then compounds 3 and 2 (each within the scatter of the next).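

In this assay, among these compounds, the swap of ethyl for methoxy on this aromatic carbon gives a number 2.6 percentage points lower from compound 2 to compound 3 (within the scatter) and is the first single-change step here. It shows that this position takes an oxygen-linked group of the same heavy-atom count, with one added hydrogen-bond acceptor, without a difference that stands out from the scatter. Nothing available explains why the two groups read alike.

On these data alone, whether an amine, chlorine or a longer chain such as propyl on this carbon would read the same remains open. So does whether ethyl and methoxy also match at other concentrations.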